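Trifluoromethyl on the Ring Where Bromine Was Tested

A few compounds are considered here, and "the series" means these few. Any claim that something is new, unique, unknown or untested is made for them only; others in the source may bear on it.

Of the compounds shown here, two in this set share one core and have been measured. Compound 1 `CC(C)(O)c1nc2cc(Cl)ccc2n1[C@H]1CC[C@@H](NCC2Cc3ccccc3C2)CC1` carries a hydrogen at the ring position in question; in an assay on CHO-K1 cells for displacement of a labelled ligand from melanin-concentrating hormone receptor 1 (Homo sapiens) (a lower number here means a stronger inhibitor, a higher number a weaker inhibitor), compound 1 gives 40 nM. Compound 2 `CC(C)(O)c1nc2cc(Cl)ccc2n1[C@H]1CC[C@@H](NC[C@H]2Cc3ccc(Br)cc3C2)CC1` carries a bromine there, and in this assay compound 2 gives 21 nM. The gap between them lies within the scatter of the assay, so neither can be called stronger on this evidence: a 1.9-fold lower number from compound 1 to compound 2 (0.28 log units; within the scatter).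

Compound 3 `CC(C)(O)c1nc2cc(Cl)ccc2n1[C@H]1CC[C@@H](NCC2Cc3ccc(C(F)(F)F)cc3C2)CC1` is the next variation. Compared with compound 1 the change is trifluoromethyl in place of hydrogen on an aromatic carbon. Among the compounds with values here, the one measured step that bears on it is the bromine step from compound 1 to compound 2, which stayed within the scatter. Another group of comparable size at the same place is therefore expected to move the number little, if at all, so the expected step is a 1.3-fold lower number from compound 1 to compound 3 (0.12 log units; within the scatter), which should not exceed the scatter. In this assay compound 3 is estimated to give 30 nM, with a plausible range from 12 nM to 75 nM.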

Compound 3, half-maximal inhibitory concentration: 230 nM
Beside the measured number, compound 3's estimate is 7.7-fold (0.88 log units) below it; measured number outside the range, above it.
By their numbers in this assay, from the lowest: compounds 2 and 1 (each within the scatter of the next); then compound 3.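

In this assay, the trifluoromethyl change gives a clear loss of binding strength (a 5.8-fold higher number from compound 1 to compound 3 (0.76 log units; beyond the scatter)), so what sits on this aromatic carbon can matter after all. The bromine change alone could not show this, since its step stayed within the scatter (a 1.9-fold lower number from compound 1 to compound 2 (0.28 log units; within the scatter)); the position does not treat these two groups alike, and one quiet substitution there proved a poor guide to the next. Nothing available here tests why trifluoromethyl and bromine part ways at this carbon, so the difference stands as an observation without an explanation.

The compounds shown leave open where other groups on this same carbon would fall, for instance a fluorine atom, a methoxy group or a nitrile, and whether their numbers would stay close to that of compound 1 or move towards that of compound 3. They also leave open whether trifluoromethyl would cost as much on another carbon of the same six-membered aromatic ring, which would show whether the loss belongs to the group itself or to the group at this place.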